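Methyl in Place of Hydrogen: Expected Cytotoxicity of Compound 4

The source may hold more compounds than are shown below. What is called first, only, known or untested is meant among the compounds shown, and "the series" means these compounds.

Of the compounds shown here, three sharing one core have been tested in an ADME assay on MT4 cells (Homo sapiens) for cytotoxicity, read by MTT assay, with a stated time of 96 h; on this read-out lower numbers stand for higher toxicity in this test and higher numbers for lower toxicity in this test. Compound 1 `O=C(CN1CCCCC1)Nc1ccc(-c2nc3cc(C(F)(F)F)ccc3[nH]2)cc1` gives 6000 nM. Compound 2 `Fc1ccc(-c2nc3cc(C(F)(F)F)ccc3[nH]2)cc1` gives 22000 nM, and compound 3 `CC(=O)Nc1ccc(-c2nc3cc(C(F)(F)F)ccc3n2C2CCCCC2)cc1` gives 24000 nM. Compound 1 therefore stands at the lowest number of the three, which on this read-out means the highest toxicity in this test; its gap to compound 2 and its gap to compound 3 both lie beyond the usual scatter, while the values of compound 2 and compound 3 sit within the scatter of each other and cannot be ordered.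

Compound 4 `Cn1c(-c2ccc(NC(=O)CN3CCCCC3)cc2)nc2cc(C(F)(F)F)ccc21` is not yet measured. Its structure differs from that of compound 1 in a single place: methyl in place of hydrogen on an aromatic nitrogen. Among the measured compounds shown here, no pair of measured compounds here differs only by methyl in place of hydrogen on an aromatic nitrogen, so the size of this step cannot be read from any measured pair. Compound 3, which carries a larger group on that nitrogen together with other changes, gives a higher number than compound 1, but it is not a clean comparison.

For compound 4 in this assay the expected step is a 1.5-fold higher number from compound 1 to compound 4 (0.18 log units; within the scatter), small and probably within the scatter, leaning toward a slightly higher number. The estimated value for compound 4 is 9000 nM, with a range from 3000 nM to 27000 nM.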

Compound 4, half-maximal cytotoxic concentration: 9000 nM
The estimate for compound 4 equals the measured number at the digits printed, and the stated range covers the measured number.
By their numbers in this assay, from the lowest: compounds 1 and 4 (each within the scatter of the next); then compounds 2 and 3 (each within the scatter of the next).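

Putting methyl in place of hydrogen on this aromatic nitrogen now has a size that can be read from a clean pair: in this assay, the step is a 1.5-fold higher number from compound 1 to compound 4 (0.18 log units; within the scatter). This single pair therefore shows that this position, on the five-membered aromatic ring and next to the ring atom that bears a large group, accepts one added carbon without a difference in this test that can be told apart from the usual scatter of repeated measurements. No independent measurement is available to explain this result.

On these data alone, it remains open whether a larger group on the same nitrogen, such as an ethyl group, a longer chain, or a chain ending in an amine or a carboxylic acid, would also stay within the scatter or would move the number beyond it. Among the compounds shown here, also open is whether methyl at this nitrogen would give a step of similar size on another compound, such as compound 2, as only one pair carrying this change can be read here.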